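Adding a trifluoromethyl group to compound 2

The compounds below may be only part of what the source reports. "The series", "measured", "known", "first", "only" and "open" are said of these compounds alone.

Compound 2 `C=C1C[C@]23C[C@@]1(O)CC[C@H]2c1ccc(OS(=O)(=O)c2ccc(C)cc2)c(C)c1[C@@H]3Cn1cc(-c2ccccc2)nn1` is the starting point. In a functional assay on A549 cells (Homo sapiens) for cytotoxicity, read by MTT assay, with a stated time of 4 days (on this read-out lower numbers stand for stronger inhibition and higher numbers for weaker inhibition), compound 2 gives > 20000 nM, which is a limit of the assay rather than a number. Compound 1 `C=C1C[C@]23C[C@@]1(O)CC[C@H]2c1ccc(OS(=O)(=O)c2ccc(C)cc2)c(C)c1[C@@H]3Cn1cc(-c2ccc(Br)cc2)nn1` carries a bromo group where compound 2 has hydrogen. In this assay compound 1 gives > 20000 nM, also a limit. Compound 3 `C=C1C[C@]23C[C@@]1(O)CC[C@H]2c1ccc(O)c(C)c1[C@@H]3Cn1cc(-c2ccccc2)nn1` lacks the (4-methylphenyl)sulfonyl group of compound 2. In this assay compound 3 gives > 20000 nM, again a limit. The steps a step that the two limits leave unreadable from compound 1 to compound 2 and a step that the two limits leave unreadable from compound 2 to compound 3 cannot be sized because of the limit of > 20000 nM in this assay, at which 3 of the 3 values shown sit.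

Compound 4 `C=C1C[C@]23C[C@@]1(O)CC[C@H]2c1ccc(OS(=O)(=O)c2ccc(C)cc2)c(C)c1[C@@H]3Cn1cc(-c2ccc(C(F)(F)F)cc2)nn1` differs from compound 2 by trifluoromethyl in place of hydrogen on an aromatic carbon. With no readable step to lean on, the change is expected to leave the value at the limit, a step of a number no higher from compound 2 to compound 4 (the limit leaves the size open). For compound 4 the estimate is 20000 nM, with a range from 8000 nM to 50000 nM, and most likely only a limit will again be reported.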

Compound 4, half-maximal inhibitory concentration: > 20000 nM
Compound 4: no number, only a limit (the forecaster's own chance of this, stated with the estimate: 80%); the middle value sits exactly at the limit.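

Compound 4, like compound 1 and compound 2, gives only a limit, so neither new step to compound 4 can be read: the limit of > 20000 nM in this assay, at which 4 of the 4 values shown sit.

The compounds shown leave open whether trifluoromethyl, bromo or hydrogen makes any real difference in this assay.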